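From 4-fluorophenoxy to 4-methylphenoxy: compound 2 to compound 4

The source may hold more compounds than are shown below. What is called first, only, known or untested is meant among the compounds shown, and "the series" means these compounds.

Compound 1 `Cc1nnsc1CO/N=C/c1c(C)nn(C)c1Oc1cccc(F)c1` gives > 50000 nM in a functional assay on HCT-116 cells (Homo sapiens) for inhibition, read by MTT assay, with a stated time of 48 h (a higher number here means a weaker inhibitor, a lower number a stronger inhibitor), which is a limit of the assay and not a number. In the same assay, compound 2 `Cc1nnsc1CO/N=C/c1c(C)nn(C)c1Oc1ccc(F)cc1` gives 30200 nM, the higher of the two numerical values. The other and nearest is from compound 3 `Cc1nnsc1CO/N=C/c1c(C)nn(C)c1Oc1ccc(Br)cc1`, at 7190 nM.

Compound 4 `Cc1ccc(Oc2c(/C=N/OCc3snnc3C)c(C)nn2C)cc1` carries methyl in place of fluoro on an aromatic carbon, para to a large group: methyl in place of fluoro on an aromatic carbon.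

Among the compounds with values here, the closest precedent is the change at the same place in compound 3, bromo in place of fluoro, with a 4.2-fold lower number from compound 2 to compound 3 (0.62 log units; beyond the scatter). The steps of an at least 1.6-fold lower number from compound 1 to compound 2 (0.21 log units; that floor lies within the scatter) and an at least 6.9-fold lower number from compound 1 to compound 3 (0.84 log units; beyond the scatter) bear on it less directly, as both start from 3-fluorophenyl. Within the data shown here, with only one measured replacement of this 4-fluoro group, a modest move towards a lower number in this assay is expected, no larger than the step to compound 3, and it may stay close to the scatter. The estimated step is a 2.2-fold lower number from compound 2 to compound 4 (0.33 log units; beyond the scatter). For compound 4 the expected value is 14000 nM, with an estimated range of 6000 nM to 35000 nM.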

Compound 4, half-maximal inhibitory concentration: 13800 nM
Beside the measured number, compound 4's estimate is 1.0-fold (0.01 log units) above it; measured number inside the range.
By their numbers in this assay, from the lowest: compounds 3 and 4 (each within the scatter of the next); then compound 2. At a limit, above all of these: compound 1.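

In this assay, the step to methyl, a 2.2-fold lower number from compound 2 to compound 4 (0.34 log units; beyond the scatter), shows that bromo is not the only replacement of the 4-fluoro group that gives a lower number beyond the scatter. Methyl and bromo cannot be separated at this place, since a 1.9-fold higher number from compound 3 to compound 4 (0.28 log units; within the scatter), so a large difference between these two groups does not appear in this assay. Compound 1 remains a limit of the assay and not a number, so an at least 3.6-fold lower number from compound 1 to compound 4 (0.55 log units; beyond the scatter) is only a floor: the limit of > 50000 nM in this assay, at which 1 of the 4 values shown sits.

On these data alone, how an amine, a methoxy group or a carboxylic acid in place of the 4-fluoro group would read in this assay stays open. Also open is whether 3-methylphenyl or 3-bromophenyl would follow the 4-substituted compounds, as the only 3-substituted compound shown, compound 1, carries fluoro and stands at the limit.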